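A few compounds are considered here, and "the series" means these few. Any claim that something is new, unique, unknown or untested is made for them only; others in the source may bear on it.

Working notes on the amine series.

Three compounds share one core and differ only in the amine at the end of the chain. Compound 1 `C[C@@H](CCCN1CCCC1)Nc1ccnc2cc(Cl)ccc12` gives 180000 nM in an assay for binding affinity, read by spectrophotometry; a higher number here means a weaker inhibitor, a lower number a stronger inhibitor. Compound 2 `C[C@@H](CCCN(C)C)Nc1ccnc2cc(Cl)ccc12` gives 150000 nM in this assay, and compound 3 `C[C@@H](CCCNC(C)(C)C)Nc1ccnc2cc(Cl)ccc12` gives 150000 nM. The three measured steps are a 1.2-fold lower number from compound 1 to compound 2 (0.08 log units; within the scatter), a 1.2-fold lower number from compound 1 to compound 3 (0.08 log units; within the scatter) and no change at the digits printed from compound 2 to compound 3 (within the scatter); none of them reaches beyond the scatter, so the three numbers are to be read as one level. Compound 3 therefore stands level with compound 2 and indistinguishable from compound 1 on the numbers in hand.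

Compound 4 `CCN(C)CCC[C@H](C)Nc1ccnc2cc(Cl)ccc12` is the next member. The change from compound 3 is ethyl(methyl)amino in place of (tert-butyl)amino on a saturated chain carbon, four bonds along the chain from a nitrogen on an aromatic ring. Every step measured so far in this series is of the same kind, a swap of one terminal amine for another at this position, and each of them stayed within the scatter. Going by the values given here, no step in the set bears on a donor being removed as a separate question, since the change from a pyrrolidin-1-yl to a dimethylamino already left the number unchanged. The expectation for compound 4 in this assay is accordingly a step of no size beyond the scatter, no change at the digits printed from compound 3 to compound 4 (within the scatter). Compound 4 is estimated at 150000 nM, with a range from 75000 nM to 300000 nM.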

Compound 4, half-maximal inhibitory concentration: 150000 nM
Estimate against measurement, compound 4: no gap at the digits printed, and the stated range covers the measured number.
By their numbers in this assay, from the lowest: compounds 2, 3, 4 and 1 (each within the scatter of the next).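

The new information is the smallest edit in the series: methyl in place of hydrogen on a saturated chain carbon bound to an amine nitrogen gives no change at the digits printed from compound 2 to compound 4 (within the scatter) in this assay and so adds a single-carbon step to the earlier swaps of whole amines. Going by these compounds, the exchange of (tert-butyl)amino, with its one hydrogen-bond donor, for ethyl(methyl)amino, with none, gives no change at the digits printed from compound 3 to compound 4 (within the scatter) and the comparison with the ring-bearing pyrrolidin-1-yl gives a 1.2-fold lower number from compound 1 to compound 4 (0.08 log units; within the scatter) so all four terminal amines now read as one level at this position, whether the amine carries a donor or not, and whether it is open-chain or ring-bearing. No measurement in hand offers an explanation for this flat result.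

All four compounds keep an amine nitrogen at the chain end, so the reading says nothing about a neutral amide or a carboxylic acid at that place. On these data alone, a shorter or longer chain carrying the same dimethylamino group also remains open, as does any change to the shared core, and these are the places where a step beyond the scatter might yet appear.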